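The source may report more compounds than this note shows. Statements on the series, on what has been measured and on what is new or still open speak of the compounds shown alone.

Of the compounds shown here, three built on one shared core have been measured so far. Compound 3 `Cc1nc(N)sc1CCCN/C(N)=N/C(=O)NC(C)c1ccco1` stands highest of the three in a functional assay on Right cardiac atrium for agonist activity at histamine H2 receptor (Cavia porcellus), with a stated time of 30 min, in the presence of a further agent that is not named here (on this read-out higher numbers stand for larger maximal responses and lower numbers for smaller maximal responses), where compound 3 gives 1. Compound 2 `COc1ccc(C(C)NC(=O)/N=C(\N)NCCCc2sc(N)nc2C)cc1` gives 0.91, and compound 1 `Cc1nc(N)sc1CCCN/C(N)=N/C(=O)NC(C)c1cccc(F)c1` gives 0.85. The step a number 0.15 higher from compound 1 to compound 3 (beyond the scatter) lies beyond the scatter, whereas the step a number 0.090 higher from compound 2 to compound 3 (within the scatter) and the step a number 0.060 higher from compound 1 to compound 2 (within the scatter) both lie within it, so only compound 1 is clearly separated from compound 3.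

Compound 4 `Cc1nc(N)sc1CCCN/C(N)=N/C(=O)NC(C)c1ccc(Cl)cc1` has not yet been measured. It differs from compound 3 in one place: 4-chlorophenyl in place of furan-2-yl on a saturated chain carbon bound to an amide-type nitrogen and a saturated chain carbon. All three measured steps bear on this change, since each of them swaps one ring for another at the same saturated chain carbon bound to an amide-type nitrogen and a saturated chain carbon. The two swaps between six-membered carbon rings and the furan-2-yl ring gave steps of small to modest size, one within and one beyond the scatter, and the swap between two six-membered carbon rings stayed within the scatter. A small downward step is therefore expected, a number 0.10 lower from compound 3 to compound 4 (within the scatter), which may itself fall within the scatter. For compound 4 the expected value is 0.9, with a range from 0.8 to 1.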

Compound 4, intrinsic activity: the largest response reached, as a fraction of the reference agonist's: 0.93
Beside the measured number, compound 4's estimate is 0.030 below it, within the range that was stated.
By their numbers in this assay, from the lowest: compounds 1, 2, 4 and 3 (each within the scatter of the next, the first and the last beyond it).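

In this assay, the step for 4-chlorophenyl in place of furan-2-yl on a saturated chain carbon bound to an amide-type nitrogen and a saturated chain carbon is a number 0.070 lower from compound 3 to compound 4 (within the scatter), so this ring swap does not separate the two compounds, whereas the swap between 3-fluorophenyl and furan-2-yl did. The same holds for chloro in place of methoxy on an aromatic carbon, with the step a number 0.020 higher from compound 2 to compound 4 (within the scatter), and for 4-chlorophenyl in place of 3-fluorophenyl, with the step a number 0.080 higher from compound 1 to compound 4 (within the scatter), so compound 4 cannot be told apart from any of the others, even though compound 1 and compound 3 are clearly separated from each other. No measurement at hand explains why these rings give such close maximal responses.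

From the compounds shown here alone, all four compounds carry an aromatic ring at this carbon, so it remains open how a saturated cyclohexyl ring or a plain methyl group would behave there. A phenyl ring bearing a carboxylic acid or an amine would also test this position with groups quite unlike chloro, fluoro and methoxy.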